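Kinetic solubility along a glycoside series: predicting compound 4

The compounds below may be only part of what the source reports. "The series", "measured", "known", "first", "only" and "open" are said of these compounds alone.

Within the data shown here, compound 3 `CC(=O)c1ccc(-c2ccc(O[C@H]3O[C@H](CO)[C@@H](O)[C@H](O)[C@@H]3O)c(Cl)c2)cc1` gives 16 ug/mL in a physicochemical assay for solubility, measured as kinetic solubility, with a stated time of 15 h, at pH 7.4 (on this read-out lower numbers stand for lower solubility and higher numbers for higher solubility), which places it second of the three numbers known so far. Compound 1 `OC[C@H]1O[C@H](Oc2ccc(-c3ccc(Cl)cc3Cl)cc2Cl)[C@@H](O)[C@@H](O)[C@@H]1O` gives 8 ug/mL, and the step of a 2.0-fold higher number from compound 1 to compound 3 (0.30 log units; within the scatter) lies within the scatter. Compound 2 `N#Cc1ccc(-c2ccc(O[C@H]3O[C@H](CO)[C@@H](O)[C@H](O)[C@@H]3O)c(Cl)c2)cc1` gives 192 ug/mL, and the step of a 12-fold lower number from compound 2 to compound 3 (1.08 log units; beyond the scatter) is large.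

Compound 4 `Cc1ccccc1-c1ccc(O[C@H]2O[C@H](CO)[C@@H](O)[C@H](O)[C@@H]2O)c(Cl)c1` differs from compound 3 in one place: 2-methylphenyl in place of 4-acetylphenyl on an aromatic carbon. The replacement removes the only hydrogen-bond acceptor of the leaving group and leaves a ring bearing only carbon. Among the measured compounds shown here, of the measured steps, the one from compound 2 to compound 3 bears most on this change, since it too exchanged a group with an acceptor for one with fewer, and it was large and downward; the step from compound 1 to compound 3 shows that two groups without an acceptor of the cyano kind sit within the scatter of each other. Therefore the expected step is a 2.3-fold lower number from compound 3 to compound 4 (0.36 log units; beyond the scatter). Compound 4 is estimated at 7 ug/mL, with a range from 2.5 ug/mL to 20 ug/mL.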

Compound 4, solubility: 135 ug/mL
Compound 4: the middle estimate sits 19-fold (1.29 log units) below what was measured; measured number above the stated range.
By their numbers in this assay, from the lowest: compounds 1 and 3 (each within the scatter of the next); then compounds 4 and 2 (each within the scatter of the next).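

In this assay, compound 4 carries a group with no hydrogen-bond acceptors at this position, yet it shows an 8.4-fold higher number from compound 3 to compound 4 (0.93 log units; beyond the scatter) and a 17-fold higher number from compound 1 to compound 4 (1.23 log units; beyond the scatter). Compound 2, whose 4-cyanophenyl group is a different ring substituent, and compound 4 stand within the scatter of each other, with a 1.4-fold lower number from compound 2 to compound 4 (0.15 log units; within the scatter) as the printed step. Among these four compounds, the loss of the acceptor in the change from 4-acetylphenyl to 2-methylphenyl therefore does not bring a lower number, and compound 4 goes against the link between acceptors and the read-out that the earlier steps seemed to suggest.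

Going by these compounds, how a phenyl ring bearing an amine or a carboxylic acid would read at this place remains open. Nothing among the data shown accounts for these differences.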